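A few compounds are considered here, and "the series" means these few. Any claim that something is new, unique, unknown or untested is made for them only; others in the source may bear on it.

Compound 1 `CN1CCC[C@@H]1Cn1nc(Cc2ccc(O)cc2)c2ccccc2c1=O` gives 398 nM in an assay for binding affinity to Alpha-1B adrenergic receptor (Homo sapiens); a higher number here means a weaker inhibitor, a lower number a stronger inhibitor.
Compound 2 `CN1CCC[C@@H]1Cn1nc(Cc2cccc(Cl)c2)c2ccccc2c1=O` gives 631 nM in this assay.

Compound 2 and compound 1 sit within the scatter of each other, as the step of a 1.6-fold higher number from compound 1 to compound 2 (0.20 log units; within the scatter) shows. Compound 3 `CN1CCC[C@@H]1Cn1nc(CC2CCCCC2)c2ccccc2c1=O` differs from compound 2 by cyclohexyl in place of 3-chlorophenyl on a saturated chain carbon bound to an aromatic carbon. Going by the values given here, the only measured step, a 1.6-fold higher number from compound 1 to compound 2 (0.20 log units; within the scatter), swaps one aromatic ring for another and stays within the scatter, so it bears only loosely on a swap to a saturated ring, for which no measured step exists. A modest weakening in this assay is therefore expected, namely a 1.6-fold higher number from compound 2 to compound 3 (0.20 log units; within the scatter). Compound 3 is estimated at 1000 nM, with a range from 300 nM to 3500 nM.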

Compound 3, inhibition constant: > 1990 nM
Compound 3 was reported as a limit (the forecaster's own chance of this, stated with the estimate: 5%); middle value at least 1.9-fold (0.29 log units) away from the limit.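

Compound 3 gives > 1990 nM in this assay as a limit, not an exact number. Putting cyclohexyl on this saturated chain carbon gives an at least 3.1-fold higher number from compound 2 to compound 3 (0.49 log units; beyond the scatter) when it replaces 3-chlorophenyl, and an at least 5.0-fold higher number from compound 1 to compound 3 (0.69 log units; beyond the scatter) when it replaces 4-hydroxyphenyl. So while the swap between the two aromatic rings stayed within the scatter, losing the aromatic ring here weakens binding beyond it. The limit leaves open how weak compound 3 really is. From the compounds shown here alone, whether an amine or a carboxylic acid on this chain carbon would restore binding also remains open.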